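The source may report more compounds than this note shows. Statements on the series, on what has been measured and on what is new or still open speak of the compounds shown alone.

Measured so far in an in vitro ADME assay on microsomes from Gut (Homo sapiens) for metabolic stability, using NADPH (on this read-out lower numbers stand for slow clearance and higher numbers for fast clearance), are three compounds:

Compound 1 `COc1ccc(OC(F)(F)F)cc1Cn1c(C(=O)NCC(C)(C)CO)cc2cc(C#N)ccc21` gives < 6 mL.min-1.g-1
Compound 2 `CCOc1ccc(OC(F)(F)F)cc1Cn1c(C(=O)NCC(C)(C)CO)cc2cc(C#N)ccc21` gives < 6 mL.min-1.g-1
Compound 3 `CC(C)(CO)CNC(=O)c1cc2cc(C#N)ccc2n1Cc1cc(Cl)cc(Cl)c1` gives < 6 mL.min-1.g-1

Compound 1 stands at < 6 mL.min-1.g-1, which is a limit of the assay and not a number. The other two compounds offer no firmer reference, as the whole set shows (the limit of < 6 mL.min-1.g-1 in this assay, at which 3 of the 3 values shown sit). Compound 4 `COc1ccc(Br)cc1Cn1c(C(=O)NCC(C)(C)CO)cc2cc(C#N)ccc21` keeps the core of compound 1 and its methoxy group and differs in one place: bromo in place of trifluoromethoxy on an aromatic carbon.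

For the measured compounds named here, the only measured step is a step that the two limits leave unreadable from compound 1 to compound 2. It lies elsewhere in the structure, and it gives no size to carry over. Going by the values given here, no measured step covers the exchange of trifluoromethoxy for bromo. Compound 3 has a differently substituted aromatic ring, and its < 6 mL.min-1.g-1 is likewise a limit. No step beyond the scatter is therefore expected in this assay, and no direction can be assigned. The expected step is a step that the limit leaves unreadable from compound 1 to compound 4. This expectation rests on compound 1 , whose < 6 mL.min-1.g-1 is a limit. For compound 4 the estimated value is 5 mL.min-1.g-1, with an expected range of 3 mL.min-1.g-1 to 10 mL.min-1.g-1.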

Compound 4, intrinsic clearance in microsomes: < 6 mL.min-1.g-1
Compound 4: no number, only a limit; the forecaster's own chance of this, stated with the estimate: 75%; the middle value does not contradict the limit.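

Compound 4, like compound 1 and compound 3, gives a limit of the assay and not a number, so no step to compound 4 from either of them can be read in this assay: the limit of < 6 mL.min-1.g-1 in this assay, at which 4 of the 4 values shown sit.

The compounds shown leave open how their clearances compare, and whether the exchange of trifluoromethoxy for bromo changes clearance at all.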